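Trimethoxybenzyl series: alkynyl chain replacing oxolanyl

The source may hold more compounds than are shown below. What is called first, only, known or untested is meant among the compounds shown, and "the series" means these compounds.

For the measured compounds named here, compound 2 `COc1cc(Cc2nc3c(N)nc(F)nc3n2CC2CCCO2)cc(OC)c1OC` gives 22900 nM in a functional assay on MCF7 cells (Homo sapiens) for antiproliferative activity (a higher number here means a weaker inhibitor, a lower number a stronger inhibitor), the second highest of the three numbers measured so far. Its nearest neighbour is compound 1 `C#CCCCn1c(Cc2cc(OC)c(OC)c(OC)c2)nc2c(N)nc(F)nc21`, which gives 11000 nM in this assay; the furthest is compound 3 `CCC(CC)Cn1c(Cc2cc(OC)c(OC)c(OC)c2)nc2c(N)ncnc21`, which gives 158000 nM and differs from the others in more than one place, so its value is noted only for position. Compound 4 `CC#CCCn1c(Cc2cc(OC)c(OC)c(OC)c2)nc2c(N)nc(F)nc21` is not yet measured; it differs from compound 2 by but-2-yn-1-yl in place of oxolan-2-yl on a saturated chain carbon bound to an aromatic nitrogen. Going by the values given here, the one measured step that bears on this change is the exchange of a chain for the ring in the same place: a 2.1-fold higher number from compound 1 to compound 2 (0.32 log units; beyond the scatter). Compound 4 carries a chain of the same length as compound 1, with the triple bond shifted, so the reverse of that step is the expected size and direction, and a modest decrease in the number is estimated, a 1.9-fold lower number from compound 2 to compound 4 (0.28 log units; within the scatter). Compound 4 is therefore expected to give about 12000 nM in this assay, with a range from 5000 nM to 30000 nM.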

Compound 4, half-maximal inhibitory concentration: 37200 nM
Compound 4: the middle estimate sits 3.1-fold (0.49 log units) below what was measured; the whole stated range lies below it.
By their numbers in this assay, from the lowest: compound 1; then compounds 2 and 4 (each within the scatter of the next); then compound 3.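

In this assay, an alkynyl chain at this place is not enough to give the lower number of compound 1: a 1.6-fold higher number from compound 2 to compound 4 (0.21 log units; within the scatter), so but-2-yn-1-yl and oxolan-2-yl in place of one another cannot be told apart here. Where the triple bond lies in the chain does register, since the two chains differ beyond the scatter, with prop-1-yn-1-yl in place of propargyl: a 3.4-fold higher number from compound 1 to compound 4 (0.53 log units; beyond the scatter). Nothing available accounts for this difference between the two alkynyl chains.

On these data alone, whether the lower number of compound 1 is specific to its chain stays open, as the series holds only one chain of that kind. It is also unknown how a longer chain or an amine at this place would compare with compound 1 and compound 2.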